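The source may report more compounds than this note shows. Statements on the series, on what has been measured and on what is new or still open speak of the compounds shown alone.

Three compounds stand behind this step: compound 1 (`O=C(/C=C/c1cccnc1)Nc1ccc(CN2C(=O)c3ccccc3C2=O)cc1`), compound 2 (`CCC(=O)NCc1ccc(NC(=O)[C@H]2C[C@@H]2c2cccnc2)cc1`) and compound 3 (`CCC(=O)NC(C)(C)c1ccc(NC(=O)[C@H]2C[C@@H]2c2cccnc2)cc1`). In a functional assay on A2780 cells (Homo sapiens) for antiproliferative activity, read by CellTiter-Glo, with a stated time of 4 days (on this read-out lower numbers stand for stronger inhibition and higher numbers for weaker inhibition), compound 1 has the entry "not determined" (no result reported) as its only record, compound 2 gives 405 nM and compound 3 gives 832 nM as the higher of the two numbers. Moving on to compound 4 (`COCC(=O)N[C@@H](C)c1ccc(NC(=O)[C@H]2C[C@@H]2c2cccnc2)cc1`) brings a group of 8 heavy atoms (5 carbon, 1 nitrogen, 2 oxygen; no ring) in place of a group of 8 heavy atoms (6 carbon, 1 nitrogen, 1 oxygen; no ring), on an aromatic carbon as the structural change. Within the data shown here, one measured step bears on it: a 2.1-fold higher number from compound 2 to compound 3 (0.31 log units; beyond the scatter) on the same aromatic carbon. Since that step is modest, only a small move is expected in this assay, toward a lower number. The estimated step is a 1.8-fold lower number from compound 3 to compound 4 (0.27 log units; within the scatter) in that direction. For compound 4 the expected value is 450 nM (estimated range 160 nM to 1200 nM).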

Compound 4, half-maximal inhibitory concentration: 30 nM
Estimate against measurement, compound 4: 15-fold (1.18 log units) above; the whole stated range lies above it.
By their numbers in this assay, from the lowest: compound 4; then compound 2; then compound 3.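

At this position, on an aromatic carbon para to a large group, a change of side chain can shift this assay far more than the earlier modest step showed, giving a 28-fold lower number from compound 3 to compound 4 (1.44 log units; beyond the scatter) and a 14-fold lower number from compound 2 to compound 4 (1.13 log units; beyond the scatter). The entering and leaving groups of compound 3 and compound 4 have equal heavy-atom counts, but the entering group has a second hydrogen-bond acceptor and a defined stereocentre. No measurement here accounts for the gain. The compounds shown leave open which of these differences carries it, and how the opposite stereoisomer, a longer chain or an amine in place of the ether oxygen would read.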